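The source may report more compounds than this note shows. Statements on the series, on what has been measured and on what is new or still open speak of the compounds shown alone.

Compound 2 `O=[N+]([O-])c1ccc(N/C(=N\O)c2cccc(Br)c2)c2nonc12` gives the lowest number among the three compounds measured in an assay on isolated protein for inhibition of Tryptophan 2,3-dioxygenase (Homo sapiens), read by spectrophotometry, with a stated time of 1 h (on this read-out higher numbers stand for weaker inhibition and lower numbers for stronger inhibition), at 20000 nM. Compound 1 `O=[N+]([O-])c1ccc(N/C(=N\O)c2cccc(F)c2)c2nonc12` gives 45000 nM and compound 3 `O=[N+]([O-])c1ccc(N/C(=N\O)c2ccc(F)cc2)c2nonc12` gives 21000 nM; the values of compound 2 and compound 3 lie within the scatter of each other. Compound 4 `O=[N+]([O-])c1ccc(N/C(=N\O)c2ccc(Br)cc2)c2nonc12` differs from compound 2 by 4-bromophenyl in place of 3-bromophenyl on a carbon with a double bond to nitrogen. Going by the values given here, the only measured step bearing on this change is a 2.1-fold lower number from compound 1 to compound 3 (0.33 log units; beyond the scatter), where the same move of a halogen from the 3-position to the 4-position of the phenyl ring brought a modest lowering. A modest lowering is therefore expected in this assay, a 1.7-fold lower number from compound 2 to compound 4 (0.22 log units; within the scatter), but it may not clear the scatter. Compound 4 is estimated at 12000 nM, within 5000 nM to 30000 nM.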

Compound 4, half-maximal inhibitory concentration: 50000 nM
Beside the measured number, compound 4's estimate is 4.2-fold (0.62 log units) below it; measured number outside the range, above it.
By their numbers in this assay, from the lowest: compounds 2 and 3 (each within the scatter of the next); then compounds 1 and 4 (each within the scatter of the next).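

In this assay, the shift to 4-bromophenyl in place of 3-bromophenyl raises the number, a 2.5-fold higher number from compound 2 to compound 4 (0.40 log units; beyond the scatter), so the lowering seen with the fluoro pair does not carry over to bromo. Compound 4 also shows no separation from the fluoro compound that gave the highest earlier number, a 1.1-fold higher number from compound 1 to compound 4 (0.05 log units; within the scatter). Bromo in place of fluoro now raises the number, a 2.4-fold higher number from compound 3 to compound 4 (0.38 log units; beyond the scatter), so the effect of that swap depends on where the halogen sits: the same change on two cores in this assay, a 2.3-fold lower number (0.35 log units; beyond the scatter) from compound 1 to compound 2 and a 2.4-fold higher number (0.38 log units; beyond the scatter) from compound 3 to compound 4, 5.4-fold (0.73 log units) apart, beyond the scatter of two such steps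

On these data alone, whether chloro, methyl or an amine on the phenyl ring would follow the bromo or the fluoro pair remains open.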